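Hydroxy in Place of Isopropoxy at the Edge of an Assay

The compounds below may be only part of what the source reports. "The series", "measured", "known", "first", "only" and "open" are said of these compounds alone.

Compound 1, `CC(C)Oc1cccc(-c2ccc(C(=O)N(Cc3cccc(OCCCCCC(=O)O)c3)C(C)C)cc2)c1`, in an ADME assay on HEK293 cells (Homo sapiens) for cytotoxicity, read by CellTiter-Glo and resazurin assay, with a stated time of 72 h (a higher number here means that more compound is needed for the effect, a lower number that less compound is needed), gives > 26000 nM, a limit of the assay.
Compound 2, `CCOC(=O)CCCCCOc1cccc(CN(C(=O)c2ccc(-c3cccc(OCC(C)C)c3)cc2)C(C)C)c1`, in this assay gives > 26000 nM, a limit of the assay.
Compound 3, `CCOC(=O)CCCCCOc1cccc(CN(C(=O)c2ccc(-c3cccc(OC(C)C)c3)cc2)C(C)C)c1`, in this assay gives > 26000 nM, a limit of the assay.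

For the measured compounds named here, compound 3 stands where every compound measured so far stands: at a limit, with no number of its own. The account now follows the step from compound 3 to compound 4, `CCOC(=O)CCCCCOc1cccc(CN(C(=O)c2ccc(-c3cccc(O)c3)cc2)C(C)C)c1`, which is not yet measured. The change is hydrogen in place of isopropyl on an oxygen on an aromatic ring.

Two measured steps lead into compound 3. The step that the two limits leave unreadable from compound 1 to compound 3 and the step that the two limits leave unreadable from compound 2 to compound 3 both join two limits, so neither shows a size. Going by the values given here, the only evidence is the limit of > 26000 nM in this assay, at which 3 of the 3 values shown sit, which tells that nothing measured here has reached a readable number; it does not tell how a change on the oxygen on the aromatic ring moves the read-out, and no step shows the isopropyl being replaced by hydrogen.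

With every neighbour at the limit and no readable step, compound 4 is expected to sit at the limit as well, with 40000 nM between 20000 nM and 100000 nM. The expected step from compound 3 is therefore a step that the limit leaves unreadable from compound 3 to compound 4, none beyond the scatter.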

Compound 4, half-maximal effective concentration: > 26000 nM
Compound 4 ended at the assay's limit; the forecaster's own chance of this, stated with the estimate: 80%; the middle value lies beyond the limit too.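

Compound 4 stays at the limit, as do compound 2 and compound 3, so the steps joining it to those two compounds cannot be read in this assay: the limit of > 26000 nM in this assay, at which 4 of the 4 values shown sit. The compounds shown leave open what readable value any of them would give, and how replacing isopropoxy with hydroxy moves the read-out.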